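Swapping a thiophene for a trifluoromethylphenyl on the shared core

The source may report more compounds than this note shows. Statements on the series, on what has been measured and on what is new or still open speak of the compounds shown alone.

Of the compounds shown here, three sharing one core have been measured in a functional assay on T47D cells (Homo sapiens) for inhibition, read by sulforhodamine B assay, with a stated time of 48 h, tested at 10 uM; a higher number here means more inhibition at the concentration tested (going by the name of the read-out), a lower number less inhibition. Compound 3 `c1csc(-c2cn3ccnc3c(-c3ccc4ncn(C5CCCCC5)c4c3)n2)c1` gives 70.3%, the highest of the three. Compound 2 `COc1ccccc1-c1cn2ccnc2c(-c2ccc3ncn(C4CCCCC4)c3c2)n1` gives 36.6%, and compound 1 `COc1ccc(-c2cn3ccnc3c(-c3ccc4ncn(C5CCCCC5)c4c3)n2)cc1` gives -8.6%. Compound 4 `FC(F)(F)c1cccc(-c2cn3ccnc3c(-c3ccc4ncn(C5CCCCC5)c4c3)n2)c1` has not been measured; it differs from compound 3 by 3-(trifluoromethyl)phenyl in place of thiophen-2-yl on an aromatic carbon. Going by the values given here, two measured steps bear on this: a number 78.9 percentage points higher from compound 1 to compound 3 (beyond the scatter) and a number 33.7 percentage points higher from compound 2 to compound 3 (beyond the scatter). Both show that the thiophen-2-yl compound sits well above the two compounds carrying a six-membered aromatic ring of carbon only, so replacing the thiophen-2-yl with another such ring is expected to lower inhibition, by about a number 35.3 percentage points lower from compound 3 to compound 4 (beyond the scatter). Compound 4 is therefore estimated at 35%, with a likely range from 0% to 65%.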

Compound 4, a percentage reported as inhibition, at one concentration (the size of the read-out at that concentration, not a potency) in the T47D assay: 52.2%
For compound 4 the middle estimate is 17.2 percentage points below the measured one; measured number inside the range.
By their numbers in the T47D assay, from the lowest: compound 1; then compound 2; then compound 4; then compound 3.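

In the T47D assay, a six-membered aromatic ring of carbon only at this position need not lose most of the inhibition: 3-(trifluoromethyl)phenyl in place of thiophen-2-yl gives a number 18.1 percentage points lower from compound 3 to compound 4 (beyond the scatter). This ring also outdoes both methoxyphenyl rings, with a number 15.6 percentage points higher from compound 2 to compound 4 (beyond the scatter) and a number 60.8 percentage points higher from compound 1 to compound 4 (beyond the scatter), so among these compounds the group on the ring matters, not just the ring itself. In a physicochemical assay for lipophilicity, using the shake flask method, in phosphate buffer, measured as octanol-water partition, with a stated time of 85 min, at pH 7.4 (a higher number here means a more lipophilic compound, a lower number a more polar compound), compound 3 gives 1.38 and compound 4 gives 1.72. Inhibition falls with this swap while the reading in the physicochemical assay moves the other way: the measured partition coefficient of compound 3, 1.38, and of compound 4, 1.72, a number 0.34 log units higher (beyond the scatter)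

As far as these compounds go, what an amine or a carboxylic acid on the phenyl ring would do to inhibition remains open.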